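The source may report more compounds than this note shows. Statements on the series, on what has been measured and on what is new or still open speak of the compounds shown alone.

The compounds share one core carrying a long chain, and they were compared in a functional assay on cells (Lymphocyte, Homo sapiens), read by a luciferase reporter and ATP content, with a stated time of 48 h, tested at 1 uM; on this read-out lower numbers stand for a stronger effect and higher numbers for a weaker effect at the one concentration tested. Compound 1 `CCCCCCCCCCCCCCc1nc(N2CCC2)nc(OC2CCC2)c1O` gives 105% in this assay. Compound 2 `CCCCCCCCCCCCCCCCc1nc(N2CCC2)nc(OC2CCC2)c1O`, which carries the longer chain, gives 100%, and compound 3 `CCCCCCCCCCCCCCc1nc(OC2CCC2)nc(OC2CCC2)c1O`, with cyclobutyloxy groups on both sides of the core, gives 99%. The two steps away from compound 1 are small: a number 5 percentage points lower from compound 1 to compound 2 (within the scatter) and a number 6 percentage points lower from compound 1 to compound 3 (within the scatter). All three numbers therefore lie within the usual scatter of one another, and compound 1 cannot be set apart from the others.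

Compound 4 `CCCCCCCCCCCCCCc1nc(N2CCC2)nc(N2CCC2)c1O` is not yet measured. It differs from compound 1 in one place: azetidin-1-yl in place of cyclobutyloxy on an aromatic carbon. Among the measured compounds shown here, the step that bears on this is the one from compound 1 to compound 3, where the same two groups were swapped the other way round on the other side of the core, and that step stayed within the scatter. For compound 4, the step of a number 2 percentage points lower from compound 1 to compound 4 (within the scatter) is therefore expected to stay within the scatter, and compound 4 is estimated at 103% in this assay, most likely between 90% and 115%.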

Compound 4, a percentage reported as activity, at one concentration (the size of the read-out at that concentration, not a potency): 86%
The estimate for compound 4 lay 17 percentage points above the measured number; the measured number lies below the stated range.
By their numbers in this assay, from the lowest: compound 4; then compounds 3, 2 and 1 (each within the scatter of the next).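

Swapping cyclobutyloxy for azetidin-1-yl on this aromatic carbon, next to the ring nitrogen and ortho to the hydroxy group, gives the first step in the series that clears the scatter in this assay: a number 19 percentage points lower from compound 1 to compound 4 (beyond the scatter), toward a stronger effect at the one concentration tested. The same two groups exchanged the other way round in the other place on the core gave only a number 6 percentage points lower from compound 1 to compound 3 (within the scatter), so the earlier step could not be carried over to this position, and what a group does here has to be read at this position itself. No measurement at hand explains why the exchange matters in this place.

Going by these compounds, whether a larger ring such as piperidin-1-yl, or an open-chain dimethylamino group, would do the same in this place remains open. So does whether the longer chain of compound 2 would change the number when combined with the two azetidin-1-yl groups of compound 4.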